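From 3,4-dimethoxybenzyl to 4-fluorobenzyl on the shared core

The source may hold more compounds than are shown below. What is called first, only, known or untested is meant among the compounds shown, and "the series" means these compounds.

In a functional assay on HCT-116 cells (Homo sapiens) for antiproliferative activity, read by MTT assay, with a stated time of 48 h (on this read-out higher numbers stand for weaker inhibition and lower numbers for stronger inhibition), compound 1 (`COc1ccc(CN(C(=O)CSc2nc3ccccc3s2)c2cc(OC)c(OC)c(OC)c2)cc1C`) gives 17100 nM and compound 2 (`COc1ccc(CN(C(=O)CSc2nc3ccccc3s2)c2cc(OC)c(OC)c(OC)c2)cc1OC`) gives 33900 nM. Among the measured compounds shown here, these are the only two numbers so far, and they lie within the scatter of each other. The next structure is compound 3 (`COc1cc(N(Cc2ccc(F)cc2)C(=O)CSc2nc3ccccc3s2)cc(OC)c1OC`), with 4-fluorophenyl in place of 3,4-dimethoxyphenyl on a saturated chain carbon bound to an amide-type nitrogen. For the measured compounds named here, the one measured step bearing on this change is a 2.0-fold higher number from compound 1 to compound 2 (0.30 log units; within the scatter), which exchanges methoxy for methyl on an aromatic carbon of the same group. Going by the values given here, it is a single, smaller exchange, and no measured pair contains the 4-fluorobenzyl group, so the guide is weak. No step beyond the scatter is therefore expected in this assay. The expected step is a 1.4-fold lower number from compound 2 to compound 3 (0.15 log units; within the scatter). For compound 3 the estimated value is 24000 nM, with an expected range of 9000 nM to 60000 nM.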

Compound 3, half-maximal inhibitory concentration: 59800 nM
Estimate against measurement, compound 3: 2.5-fold (0.40 log units) below, and the stated range covers the measured number.
By their numbers in this assay, from the lowest: compounds 1, 2 and 3 (each within the scatter of the next, the first and the last beyond it).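

Working notes on the benzyl position in this assay: putting 4-fluorophenyl in place of 3,4-dimethoxyphenyl on a saturated chain carbon bound to an amide-type nitrogen gives a 1.8-fold higher number from compound 2 to compound 3 (0.25 log units; within the scatter), so this read-out does not separate the two groups, even though both methoxy groups leave and fluorine enters. Among the compounds shown here, measured against the 4-methoxy-3-methylphenyl group, the same position gives a 3.5-fold higher number from compound 1 to compound 3 (0.54 log units; beyond the scatter), the first step beyond the scatter, though a modest one, and it points to weaker inhibition with 4-fluorophenyl. No measurement at hand accounts for either step.

On these data alone, whether an unsubstituted phenyl, a 4-chlorophenyl or a phenyl carrying an amine or a carboxylic acid would sit nearer compound 1 or compound 3 stays open. As far as these compounds go, whether the step seen here holds on any other core also stays open.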